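Anilino swap on the shared core: compound 2 to compound 3

The source may hold more compounds than are shown below. What is called first, only, known or untested is meant among the compounds shown, and "the series" means these compounds.

Of the compounds shown here, two have been measured. Compound 1 `C#CCSc1nc(Nc2ccccc2Cl)c(C#N)c(-c2ccccc2)n1` is one; compound 2 `COc1ccc(Nc2nc(SCc3cn(Cc4ccccc4Cl)nn3)nc(-c3ccccc3)c2C#N)cc1` is the other. In a functional assay on MGC-803 cells (Homo sapiens) for inhibition, read by MTT assay, with a stated time of 72 h (a lower number here means a stronger inhibitor, a higher number a weaker inhibitor), compound 1 gives 52800 nM. In this assay compound 2 gives 7560 nM, the lowest of the two numbers, and the gap to compound 1 lies beyond the scatter. Compound 3 `N#Cc1c(Nc2cccc(Cl)c2)nc(SCc2cn(Cc3ccccc3Cl)nn2)nc1-c1ccccc1` has not yet been measured. It differs from compound 2 in one place: 3-chlorophenyl in place of 4-methoxyphenyl on a nitrogen on an aromatic ring. For the measured compounds named here, no measured pair isolates this change, so its effect is unknown from the data. The expectation for the step from compound 2 to compound 3 is a small move toward a higher number, a 1.3-fold higher number from compound 2 to compound 3 (0.10 log units; within the scatter), likely not beyond the scatter. Compound 3 is therefore estimated at 9500 nM in this assay, with a range from 3000 nM to 30000 nM.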

Compound 3, half-maximal inhibitory concentration: 15800 nM
For compound 3 the middle estimate is 1.7-fold (0.22 log units) below the measured one, within the range that was stated.
By their numbers in this assay, from the lowest: compound 2; then compound 3; then compound 1.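

In this assay this position gets its first single-change comparison: 3-chlorophenyl in place of 4-methoxyphenyl on the nitrogen gives a 2.1-fold higher number from compound 2 to compound 3 (0.32 log units; beyond the scatter) and so shows that the aryl group here does register in the read-out. The step is modest and rests on one pair, so it shows sensitivity at this position but no trend across substituents. Nothing at hand accounts for the step.

The compounds shown leave open whether the step follows the change of substituent or its place on the phenyl ring, a question that (4-chlorophenyl)amino at this nitrogen would separate. Also open, going by these compounds, is how an unsubstituted phenyl, or a phenyl carrying a carboxylic acid or an amine, would read at this position on the shared core.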